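Swapping the Aryl on the Triazole of a Spiro Core

A few compounds are considered here, and "the series" means these few. Any claim that something is new, unique, unknown or untested is made for them only; others in the source may bear on it.

Compound 1 `N#CC1=C(N)Oc2c(N)cc3nc4ccccc4nc3c2C12C(=O)N(Cc1cnnn1-c1cccc(Br)c1)c1ccccc12` gives in a functional assay on HepG2 cells (Homo sapiens) for antiproliferative activity, read by MTT assay, with a stated time of 48 h (a lower number here means a stronger inhibitor, a higher number a weaker inhibitor), compound 1 the limit > 50000 nM.
Compound 2 `CCOc1ccc(-n2nncc2CN2C(=O)C3(C(C#N)=C(N)Oc4c(N)cc5nc6ccccc6nc5c43)c3ccccc32)cc1` gives in this assay compound 2 the limit > 50000 nM.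
Compound 3 `CCOc1ccccc1-n1nncc1CN1C(=O)C2(C(C#N)=C(N)Oc3c(N)cc4nc5ccccc5nc4c32)c2ccccc21` gives in this assay compound 3 the value 30500 nM.

Within the data shown here, compound 3 is thus the only one with a number; the other two sit at the limit of > 50000 nM in this assay, at which 2 of the 3 values shown sit. Compound 4 `CCc1cccc(CC)c1-n1nncc1CN1C(=O)C2(C(C#N)=C(N)Oc3c(N)cc4nc5ccccc5nc4c32)c2ccccc21` carries 2,6-diethylphenyl in place of 2-ethoxyphenyl on an aromatic nitrogen. The steps that touch this position are an at least 1.6-fold lower number from compound 1 to compound 3 (0.21 log units; that floor lies within the scatter) and an at least 1.6-fold lower number from compound 2 to compound 3 (0.21 log units; that floor lies within the scatter), both mere floors, while a step that the two limits leave unreadable from compound 1 to compound 2 gives no size. None covers a 2,6-diethylphenyl, so no direction beyond the scatter is expected, and the assay may well report only a limit again. For compound 4 the estimate is 40000 nM, between 15000 nM and 100000 nM, meaning an expected step of a 1.3-fold higher number from compound 3 to compound 4 (0.12 log units; within the scatter).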

Compound 4, half-maximal inhibitory concentration: 16500 nM
Compound 4: the middle estimate sits 2.4-fold (0.38 log units) above what was measured; the measured number falls inside the stated range.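

At this aromatic nitrogen, the change of aryl group now produces steps beyond the scatter: an at least 3.0-fold lower number from compound 2 to compound 4 (0.48 log units; beyond the scatter) and an at least 3.0-fold lower number from compound 1 to compound 4 (0.48 log units; beyond the scatter). The 2,6-diethylphenyl has no hydrogen-bond acceptor, yet a 1.8-fold lower number from compound 3 to compound 4 (0.27 log units; within the scatter), so the acceptor of 2-ethoxyphenyl is not needed to give a measurable number in this assay. Both larger steps are floors rather than sizes, set by a limit of the assay: the limit of > 50000 nM in this assay, at which 2 of the 4 values shown sit.

Going by these compounds, whether an amine, a carboxylic acid or a chain longer than ethyl on this aryl ring would lower the number further remains open. The step between the two compounds at the limit cannot be read.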